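A few compounds are considered here, and "the series" means these few. Any claim that something is new, unique, unknown or untested is made for them only; others in the source may bear on it.

Working notes on the series. In a toxicity assay on L02 cells (Homo sapiens) for cytotoxicity, read by MTT assay, with a stated time of 72 h (on this read-out higher numbers stand for weaker inhibition and lower numbers for stronger inhibition), compound 1 `O=C1c2c[n+]([O-])c3ccccc3c2C(=O)c2c1c1ccccc1n2CCCCn1ccnc1` gives 150 nM, compound 2 `CN1CCN(CCCCn2c3c(c4ccccc42)C(=O)c2c[n+]([O-])c4ccccc4c2C3=O)CC1` gives 80 nM and compound 3 `O=C1c2c[n+]([O-])c3ccccc3c2C(=O)c2c1c1ccccc1n2CCN1CCCCC1` gives 1050 nM. Compound 3 thus has the highest number of the three, and its steps to both others lie beyond the scatter.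

Compound 4 `O=C1c2c[n+]([O-])c3ccccc3c2C(=O)c2[nH]c3ccccc3c21` carries hydrogen in place of 2-(piperidin-1-yl)ethyl on an aromatic nitrogen.

Among the compounds with values here, three measured steps bear on this, all of them changes within the chain on that aromatic nitrogen. The modest one is a 7.0-fold higher number from compound 1 to compound 3 (0.85 log units; beyond the scatter), and the large one is a 13-fold higher number from compound 2 to compound 3 (1.12 log units; beyond the scatter). The third, a 1.9-fold lower number from compound 1 to compound 2 (0.27 log units; within the scatter), stays within the scatter. Within the data shown here, none of them removes the chain altogether, so the series holds no direct precedent for this change, and the chain steps serve only as a guide to how far the number can move.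

Among the measured compounds shown here, with compound 3 already at the top of the measured numbers, a small move towards stronger inhibition is expected, but no step clearly beyond the scatter. The expected step is a 1.8-fold lower number from compound 3 to compound 4 (0.24 log units; within the scatter), and it is uncertain in both directions. For compound 4 the estimated value in this assay is 600 nM, with an expected range from 150 nM to 2400 nM.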

Compound 4, half-maximal inhibitory concentration: 400 nM
Compound 4: the middle estimate sits 1.5-fold (0.18 log units) above what was measured; low and high end bracket the measured number.
By their numbers in this assay, from the lowest: compounds 2 and 1 (each within the scatter of the next); then compound 4; then compound 3.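

In this assay, taking the whole chain off the aromatic nitrogen does not push the number up: hydrogen in place of 2-(piperidin-1-yl)ethyl gives a 2.6-fold lower number from compound 3 to compound 4 (0.42 log units; beyond the scatter). Against the two butyl chains the same change goes the other way, with hydrogen in place of 4-(4-methylpiperazin-1-yl)butyl giving a 5.0-fold higher number from compound 2 to compound 4 (0.70 log units; beyond the scatter) and hydrogen in place of 4-(1H-imidazol-1-yl)butyl giving a 2.7-fold higher number from compound 1 to compound 4 (0.43 log units; beyond the scatter), so a chain at this position can lower or raise the number relative to hydrogen, depending on which chain it is. No measurement at hand accounts for this difference between the chains.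

Among the compounds shown, chain length and end group change together, since the ethyl chain carries only piperidin-1-yl and the butyl chains carry only 1H-imidazol-1-yl or 4-methylpiperazin-1-yl. On these data alone, it therefore stays open whether length or end group sets the direction of the step from hydrogen, a question that a 4-(piperidin-1-yl)butyl chain or a 2-(4-methylpiperazin-1-yl)ethyl chain on the same aromatic nitrogen would address.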